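Nitrophenyl for Methoxyphenyl, Cytotoxicity Expected to Stay Absent

This account rests on a few compounds, and the source may have more. Where it says the series, first, only, none or still open, it means among the compounds named here.

Compound 3 `CCn1cc(C(=O)N2N=C(c3cc4ccccc4o3)CC2c2ccccc2OC)c(=O)c2ccc(C)nc21` stands at a limit in an ADME assay on Vero cells (Chlorocebus sabaeus) for cytotoxicity, read by MTT assay, with a stated time of 72 h; on this read-out higher numbers stand for weaker inhibition and lower numbers for stronger inhibition: in this assay compound 3 gives > 187000 nM, which is a limit of the assay and not a number. Compound 1 `O=C(O)c1ccccc1C1CC(c2cc3ccccc3o2)=NN1C(=O)c1ccncc1` likewise reaches only a limit, > 170000 nM. Compound 2 `O=C(c1ccncc1)N1N=C(c2cc3ccccc3o2)CC1c1ccccc1[N+](=O)[O-]` also reaches only a limit, > 245000 nM. Every value shown in this assay is thus a limit, as the limit of > 170000 nM in this assay, at which 1 of the 3 values shown sits, the limit of > 187000 nM in this assay, at which 1 of the 3 values shown sits, and the limit of > 245000 nM in this assay, at which 1 of the 3 values shown sits, make plain. Among the measured compounds shown here, the one step between measured compounds, a step that the two limits leave unreadable from compound 1 to compound 2, cannot be read in size, so no measured step gives a direction to build on.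

Compound 4 `CCn1cc(C(=O)N2N=C(c3cc4ccccc4o3)CC2c2cccc([N+](=O)[O-])c2)c(=O)c2ccc(C)nc21` differs from compound 3 by 3-nitrophenyl in place of 2-methoxyphenyl on a saturated ring carbon. For the measured compounds named here, the only precedent for a nitro group entering is a step that the two limits leave unreadable from compound 1 to compound 2, which left both ends at a limit. Compound 4 is therefore expected to sit at a limit as well, with an estimate of 200000 nM in this assay, spanning 100000 nM to 500000 nM. The expected step that the limit leaves unreadable from compound 3 to compound 4 is estimated to lie within the scatter.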

Compound 4, half-maximal inhibitory concentration: > 164000 nM
Compound 4: a limit, no number; the forecaster's own chance of this, stated with the estimate: 85%; the middle value does not contradict the limit.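

In this assay compound 3 and compound 4 both stand at a limit and not at a number, so the step between them cannot be read. The compounds shown leave open the concentration at which any of them reaches half-maximal inhibition, and whether any change on the shared core alters it.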